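The compounds below may be only part of what the source reports. "The series", "measured", "known", "first", "only" and "open" are said of these compounds alone.

Measured compounds:

Compound 1, `COc1cc(NC(C)CCCNC(=O)Nc2ccc(Cl)c(C(F)(F)F)c2)c2ncccc2c1`: 3600 nM
Compound 2, `O=C(NC(c1ccccc1)c1ccc(Cl)cc1)n1nnc2ccccc21`: 67000 nM

Of the compounds shown here, two have been measured in a functional assay on L1210 cells (Mus musculus) for inhibition, read by MTT assay, with a stated time of 4 days; a lower number here means a stronger inhibitor, a higher number a weaker inhibitor. Compound 1 gives 3600 nM, the lowest number of the two. Its nearest neighbour is compound 2, which in this assay gives 67000 nM, a gap that lies beyond the usual scatter. Among the measured compounds shown here, the two share no common core, so no single structural step links them.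

The unmeasured compound 3, `COc1cc(NC(C)CCCNC(=O)NNC(=O)NC(CO)(CO)CO)c2ncccc2c1`, keeps the core of compound 1 and the urea but changes the far end: ((2-hydroxy-1,1-bis(hydroxymethyl)ethyl)carbamoyl)amino in place of 4-chloro-3-(trifluoromethyl)phenyl on an amide-type nitrogen. For the measured compounds named here, no measured pair shows a change of this kind, so the expectation rests only on compound 1 and the size of the change. The step from compound 1 to compound 3 is expected to be a loss, an 8.3-fold higher number from compound 1 to compound 3 (0.92 log units; beyond the scatter), clearly beyond the scatter. Compound 3 is estimated at 30000 nM, within a range from 8000 nM to 150000 nM.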

Compound 3, half-maximal inhibitory concentration: > 250000 nM
Compound 3 gave a limit, no number; the forecaster's own chance of this, stated with the estimate: 15%; middle value at least 8.3-fold (0.92 log units) away from the limit.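

In this assay compound 3 gives a limit and not a number: the limit of > 250000 nM in this assay, at which 1 of the 3 values shown sits. With the core and the urea kept, ((2-hydroxy-1,1-bis(hydroxymethyl)ethyl)carbamoyl)amino in place of 4-chloro-3-(trifluoromethyl)phenyl on the amide-type nitrogen gives an at least 69-fold higher number from compound 1 to compound 3 (1.84 log units; beyond the scatter), a large step. This shows that the reading in this assay depends strongly on what sits at this position, which compound 1 and compound 2 could not show, as they share no common core.

The one change removes the aromatic ring and adds hydrogen-bond donors and acceptors together, and the compounds shown do not separate these two differences. Going by these compounds, it remains open how a plain phenyl, a 4-chlorophenyl or a simple alkyl chain on this nitrogen would read in this assay.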